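A few compounds are considered here, and "the series" means these few. Any claim that something is new, unique, unknown or untested is made for them only; others in the source may bear on it.

In an ADME assay on BTI cells for inhibition of Amine oxidase [flavin-containing] A (Homo sapiens), read by fluorescence and Amplex Red, with a stated time of 15 min, tested at 100 uM (a lower number here means less inhibition, a higher number more inhibition at the concentration tested (going by the name of the read-out)), three compounds have been measured so far. Compound 1, `C#CCN(C)CCCCCCOc1ccc2c(c1)CCCC2=O`, gives 25%. Compound 2, `C#CCN(C)CCCOc1ccc2c(c1)OCCC2=O`, gives 32.1%. Compound 3, `C#CCN(C)CCCCOc1ccc2c(c1)OCCC2=O`, gives 22.8%, the lowest of the three numbers, but its gap to compound 1 and its gap to compound 2 both lie within the scatter, so no order among the three can be read from them.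

Compound 4, `C#CCN(C)CCCCCCOc1ccc2c(c1)OCCC2=O`, has not yet been measured. It differs from compound 3 in one place: 2-(methyl(propargyl)amino)ethyl in place of methyl(propargyl)amino on a saturated chain carbon, four bonds along the chain from an oxygen on an aromatic ring. The saturated chain linking the ring oxygen to the nitrogen simply grows longer, while the shared core of compounds 2, 3 and 4 is kept. For the measured compounds named here, one measured step bears on this kind of change: making the same chain longer by one carbon gave a number 9.3 percentage points lower from compound 2 to compound 3 (within the scatter), a shift that is within the scatter. Compound 1 carries the longer chain of compound 4 on a different core, and its number sits close to that of compound 3. Nothing here points to a change beyond the scatter.

The step from compound 3 to compound 4 is therefore expected to be a number 0.2 percentage points higher from compound 3 to compound 4 (within the scatter). Compound 4 is expected to give 23%. For compound 4 the likely range is estimated from 10% to 38%.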

Compound 4, a percentage reported as inhibition, at one concentration (the size of the read-out at that concentration, not a potency): 34.1%
Compound 4: the middle estimate sits 11.1 percentage points below what was measured, within the range that was stated.
By their numbers in this assay, from the lowest: compounds 3, 1, 2 and 4 (each within the scatter of the next, the first and the last beyond it).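

Lengthening the saturated chain on the shared core of this assay now moves the number beyond the scatter: with 2-(methyl(propargyl)amino)ethyl in place of methyl(propargyl)amino, on a saturated chain carbon, four bonds along the chain from an oxygen on an aromatic ring, the result is a number 11.3 percentage points higher from compound 3 to compound 4 (beyond the scatter). This is a modest step, but the earlier change of chain length on this core, a number 9.3 percentage points lower from compound 2 to compound 3 (within the scatter), did not show that the chain could move the number beyond the scatter, and the two steps do not form a steady trend: compound 2 gives 32.1% and compound 4 gives 34.1%, which lie within the scatter of each other. No measured information on these compounds accounts for the step.

For the compounds shown here, a longer chain than the one in compound 4 would show whether the number stays at this level or moves again. Also open, going by these compounds, is how the chain lengths compare when the propargyl group on the nitrogen gives way to a simple ethyl group, and since each number comes from one concentration, none of them gives a potency.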